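The source may report more compounds than this note shows. Statements on the series, on what has been measured and on what is new or still open speak of the compounds shown alone.

Compound 1 `OC[C@H]1O[C@@H](n2cnc3c(SCC4CCCCC4)ncnc32)[C@H](O)[C@@H]1O`: 1550 nM
Compound 2 `CC(C)(Sc1ncnc2c1ncn2[C@@H]1O[C@H](CO)[C@@H](O)[C@H]1O)c1ccccc1`: 21400 nM
Compound 3 `CC(C)c1ccc(CSc2ncnc3c2ncn3[C@@H]2O[C@H](CO)[C@@H](O)[C@H]2O)cc1`: 4790 nM

Three compounds share one core and differ only in the group attached through a sulfur. In an assay on isolated protein for binding affinity to Equilibrative nucleoside transporter 1 (Homo sapiens) (on this read-out higher numbers stand for weaker inhibition and lower numbers for stronger inhibition), compound 1 gives 1550 nM, the lowest number of the three. Compound 3 stands second: the change from a cyclohexyl to a 4-isopropylphenyl brought a 3.1-fold higher number from compound 1 to compound 3 (0.49 log units; beyond the scatter). Compound 2 sits furthest away, with 21400 nM in this assay; replacing cyclohexylmethyl with 1-methyl-1-phenylethyl gave a 14-fold higher number from compound 1 to compound 2 (1.14 log units; beyond the scatter).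

Compound 4 `OC[C@H]1O[C@@H](n2cnc3c(SCCCc4ccccc4)ncnc32)[C@H](O)[C@@H]1O` has not yet been measured. It arises from compound 3 by the change (phenethyl in place of 4-isopropylphenyl on a saturated chain carbon bound to a sulfur), so the ring loses its isopropyl and the chain between sulfur and ring grows. The step from compound 1 to compound 3 was modest, and the step from compound 1 to compound 2 was large. Compound 4 keeps an unbranched chain like compound 1, so its number is expected to land near compound 3 or somewhat lower, a step of a 1.6-fold lower number from compound 3 to compound 4 (0.20 log units; within the scatter). The estimate for compound 4 in this assay is 3000 nM, within a range from 1000 nM to 9000 nM.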

Compound 4, half-maximal inhibitory concentration: 1350 nM
Compound 4: the middle estimate sits 2.2-fold (0.35 log units) above what was measured; low and high end bracket the measured number.
By their numbers in this assay, from the lowest: compounds 4 and 1 (each within the scatter of the next); then compound 3; then compound 2.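

The 3-phenylpropyl group of compound 4 shows that an aromatic ring on the sulfur-bound chain need not weaken inhibition, since replacing the cyclohexyl of compound 1 with phenethyl on that chain carbon leaves the number unchanged within the scatter (a 1.1-fold lower number from compound 1 to compound 4 (0.06 log units; within the scatter)). Among these compounds, the ring alone therefore does not set the number in this assay: the unbranched chain of compound 4 stands well apart from the branched 1-methyl-1-phenylethyl group (a 16-fold lower number from compound 2 to compound 4 (1.20 log units; beyond the scatter)), and removing the isopropyl while lengthening the chain also lowers the number (a 3.5-fold lower number from compound 3 to compound 4 (0.55 log units; beyond the scatter)). Nothing given here explains these differences.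

That last step makes two changes at once, so the separate contributions of the isopropyl and the chain length stay unresolved. A plain benzyl group on the sulfur would separate them, while a longer chain or a terminal amine remains an open question at this position.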